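Notes on a protein kinase activator series

The source may hold more compounds than are shown below. What is called first, only, known or untested is meant among the compounds shown, and "the series" means these compounds.

Compound 1 `Cc1cc(C(=O)O)ccc1CN1CCC[C@H](O[C@H](CO)c2cc(Cl)cc(Cl)c2)[C@@H]1c1cccnc1` carries pyridin-3-yl on a saturated ring carbon next to the ring nitrogen of the shared core. In an assay on isolated protein for activation of cGMP-dependent protein kinase 1 (Homo sapiens), read by ADP-Glo, with stated times of 30 min and 2 h, in the presence of a further agent that is not named here (on this read-out higher numbers stand for an effect only at larger amounts of compound and lower numbers for an effect already at smaller amounts), compound 1 gives 47000 nM, the highest of the three numbers recorded so far. Compound 3 `Cc1cc(C(=O)O)ccc1CN1CCC[C@@]2(C[C@@H](c3ccccc3)CO2)[C@@H]1c1ccccc1` gives 43000 nM, which lies within the scatter of compound 1, so no order between these two can be read. Compound 2 `Cc1cc(C(=O)O)ccc1CN1CCC[C@H](O[C@@H](CC(C)(C)O)c2cc(Cl)cc(Cl)c2)[C@@H]1c1ccccc1` gives 330 nM, a number far beyond the scatter from compound 1; compound 2 differs from compound 1 in more than one place, so its values say nothing about any single exchange.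

Compound 4 `Cc1cc(C(=O)O)ccc1CN1CCC[C@H](O[C@H](CO)c2cc(Cl)cc(Cl)c2)[C@@H]1C1CCCCC1` is the next analogue to be measured: cyclohexyl in place of pyridin-3-yl on a saturated ring carbon. Within the data shown here, no measured pair isolates this exchange, and compound 2 with its phenyl and different side chain is no guide. The expectation is that the step of a 1.6-fold lower number from compound 1 to compound 4 (0.19 log units; within the scatter) stays within the usual scatter, with no clear direction. Compound 4 is therefore estimated at 30000 nM, with a range from 8000 nM to 120000 nM.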

Compound 4, half-maximal effective concentration: 65000 nM
Compound 4: the middle estimate sits 2.2-fold (0.34 log units) below what was measured, within the range that was stated.
By their numbers in this assay, from the lowest: compound 2; then compounds 3, 1 and 4 (each within the scatter of the next).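

In this assay, among these compounds, cyclohexyl in place of pyridin-3-yl on a saturated ring carbon gives a 1.4-fold higher number from compound 1 to compound 4 (0.14 log units; within the scatter), the first single exchange that can be read. At this position, with this side chain, replacing the aromatic ring with its ring nitrogen and hydrogen-bond acceptor by a non-aromatic ring of carbon only produces no change that can be told from the scatter. No measurement on hand offers an explanation for this result.

From the compounds shown here alone, whether a smaller group such as methyl, or a group with an amine such as aminomethyl, would shift the number at this position remains open. Also open, going by these compounds, is whether the same exchange would stay within the scatter on the side chain of compound 2.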